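This account rests on a few compounds, and the source may have more. Where it says the series, first, only, none or still open, it means among the compounds named here.

Among the compounds with values here, compound 1 `Cc1ccc(OCC(=O)N(Cc2cccs2)CC(C)C)cc1` sits second highest among the three numbers measured so far in an assay on HEK293 cells for agonist activity at transient receptor potential cation channel subfamily M member 8 (Homo sapiens), read by fluorescence and calcium flux, with a stated time of 15 min (a lower number here means that less compound is needed, a higher number that more compound is needed for the effect), where compound 1 gives 900 nM. Compound 2 `CCCc1ccc(OCC(=O)N(CC)Cc2cccs2)cc1` is its nearest neighbour; in this assay compound 2 gives 1810 nM, a number within the scatter of that of compound 1, so the two cannot be told apart. Compound 3 `CCN(Cc1ccsc1)C(=O)COc1ccc(C)cc1` stands furthest away, and in this assay compound 3 gives 88 nM, which lies well beyond the scatter from compound 1.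

Compound 4 `Cc1ccc(OCC(=O)N(Cc2cccs2)c2nccs2)cc1` has not yet been measured. It differs from compound 1 in a single place: 1,3-thiazol-2-yl in place of isobutyl on an amide-type nitrogen. The amide-type nitrogen that carried a saturated chain in compound 1 now carries a five-membered aromatic ring instead.

Within the data shown here, no pair of measured compounds differs in only this way, so there is no measured step to lean on, and the three measured compounds differ from each other in more than one place at once. The expectation is therefore a cautious one: a step from compound 1 to compound 4 of a 1.3-fold higher number from compound 1 to compound 4 (0.12 log units; within the scatter), with the range kept wide to allow a shift in either direction. Compound 4 is expected to give about 1200 nM in this assay, between 300 nM and 5000 nM.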

Compound 4, half-maximal effective concentration: 2240 nM
The estimate for compound 4 lay 1.9-fold (0.27 log units) below the measured number; measured number inside the range.
By their numbers in this assay, from the lowest: compound 3; then compounds 1, 2 and 4 (each within the scatter of the next, the first and the last beyond it).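

Replacing the saturated isobutyl chain on the amide-type nitrogen with the aromatic 1,3-thiazol-2-yl ring gives a 2.5-fold higher number from compound 1 to compound 4 (0.40 log units; beyond the scatter) in this assay, a modest step but one beyond the scatter. Within the data shown here, this is the first comparison in which only one place changes, so it shows that what this nitrogen carries can on its own alter the amount of compound needed for the effect. The ring also brings hydrogen-bond acceptors that isobutyl lacks, yet compound 4 still needs more compound than compound 1, and no measurement here explains this step.

A single pair cannot separate the effect of losing the isobutyl chain from that of gaining this particular ring, and a plain phenyl ring or a cyclopropyl group on the same nitrogen would help to tell these apart. Going by these compounds, it also remains open how a chain ending in an amine or a carboxylic acid would fare at this position, so the step describes one exchange rather than a rule for the position.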